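Swapping a thiophene arm for cyclohexyl on an amide antagonist

The source may hold more compounds than are shown below. What is called first, only, known or untested is meant among the compounds shown, and "the series" means these compounds.

Compound 1, `CC(C)c1cc(NC(=O)c2ccc(Cl)cc2Cl)ccc1O`, is the simplest member of this small set. In an assay on isolated protein for antagonist activity at Bile acid receptor (Homo sapiens), read by HTRF, with a stated time of 30 min (on this read-out higher numbers stand for weaker inhibition and lower numbers for stronger inhibition), compound 1 reports only a limit, > 100000 nM, so no number is known for it. Compound 2, `CC(C)(C)c1cc(NC(=O)c2c(Cl)cc(NCc3cccs3)cc2Cl)ccc1O`, carries the shared core with an added ((thiophen-2-yl)methyl)amino group, and in this assay compound 2 gives 8600 nM. For the measured compounds named here, that is the only actual number in the set. The other entry, that of compound 1, is the limit of > 100000 nM in this assay, at which 1 of the 2 values shown sits. Going by the values given here, no measured pair differs in a single place, so no measured step is available to lean on.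

Compound 3, `CC(C)(C)c1cc(NC(=O)c2c(Cl)cc(NC3CCCCC3)cc2Cl)ccc1O`, is the untested partner of compound 2. The change is cyclohexyl in place of (thiophen-2-yl)methyl on a nitrogen on an aromatic ring: one five-membered aromatic ring with one hetero atom leaves and one six-membered non-aromatic ring of carbon only enters, with the nitrogen on the aromatic ring kept. Among the compounds with values here, with no measured step of this kind to guide it, the expectation is a small step, within the scatter or only just beyond it, towards weaker inhibition, a 1.4-fold higher number from compound 2 to compound 3 (0.14 log units; within the scatter). For compound 3 the estimated value is 12000 nM, with a range from 4000 nM to 40000 nM.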

Compound 3, half-maximal inhibitory concentration: 2500 nM
For compound 3 the middle estimate is 4.8-fold (0.68 log units) above the measured one; measured number outside the range, below it.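

In this assay, for the compounds shown here, the earlier compounds gave no measured step at this position, and now there is one: putting cyclohexyl in place of (thiophen-2-yl)methyl gives a 3.4-fold lower number from compound 2 to compound 3 (0.54 log units; beyond the scatter), which means stronger inhibition. So, within this pair, neither an aromatic ring nor a sulfur atom on this arm is needed for activity. A six-membered non-aromatic ring of carbon only does better than the five-membered aromatic ring it replaces. The change also removes the one-carbon link between ring and nitrogen, so a single pair cannot separate the effect of the ring swap from the effect of losing that link, and nothing shown here gives a cause for the step.

From the compounds shown here alone, what stays open is how far this trend runs, since one step is a single comparison and not a rule: a cyclohexylmethyl group would separate the ring from the link, while a smaller cyclopentyl, an open-chain hexyl or a plain amino group would show how much of the arm is needed at all. A morpholine ring or a carboxylic acid on the cyclohexyl ring would test whether this position accepts hetero atoms.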